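The source may report more compounds than this note shows. Statements on the series, on what has been measured and on what is new or still open speak of the compounds shown alone.

The account concerns two compounds measured in an ADME assay on Caco-2 cells (Homo sapiens) for permeability, in the apical to basolateral direction (a higher number here means that the compound crosses the layer faster, a lower number that the compound crosses the layer more slowly), and a further compound that has not yet been run. Compound 1 `Cc1ccc(C(=O)Nc2cn3ncnc3c(O[C@H]3CCN(C(=O)CC(C(F)(F)F)C(F)(F)F)[C@@H](C)C3)c2C)cn1` gives 31 10^-6 cm/s in this assay. Compound 2 `Cc1ccc(C(=O)Nc2cn3ncnc3c(CN3CCN(C(=O)C4CCCC4)[C@@H](C)C3)c2C)cn1` gives 2.5 10^-6 cm/s in this assay, the lower of the two numbers, and its gap to compound 1 lies beyond the usual scatter. Compound 3 `Cc1ccc(C(=O)Nc2cn3ncnc3c(CN3CCN(C(=O)CC(C(F)(F)F)C(F)(F)F)[C@@H](C)C3)c2C)cn1` is the compound still to be measured. It differs from compound 2 in one place: 3,3,3-trifluoro-2-(trifluoromethyl)propyl in place of cyclopentyl on a carbonyl carbon. Among the measured compounds shown here, no pair of measured compounds differing in exactly this way is available, so the size of this step cannot be read off directly. The same 3,3,3-trifluoro-2-(trifluoromethyl)propyl group sits on the carbonyl carbon of compound 1, whose value of 31 10^-6 cm/s is only a loose pointer. The rest of the structure of compound 1 differs from compound 2 as well. The step of a 2.4-fold higher number from compound 2 to compound 3 (0.38 log units; beyond the scatter) is expected to be a moderate rise, of a size that may or may not clear the scatter. Compound 3 is therefore estimated to give 6 10^-6 cm/s in this assay, within a range from 2 10^-6 cm/s to 16 10^-6 cm/s.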

Compound 3, apparent permeability: 9.6 10^-6 cm/s
Compound 3: the middle estimate sits 1.6-fold (0.20 log units) below what was measured; the measured number falls inside the stated range.
By their numbers in this assay, from the lowest: compound 2; then compound 3; then compound 1.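

In this assay, the change from cyclopentyl to 3,3,3-trifluoro-2-(trifluoromethyl)propyl on a carbonyl carbon now has a size of its own: a 3.8-fold higher number from compound 2 to compound 3 (0.58 log units; beyond the scatter) is a modest step, read with the rest of the structure held the same. Among the compounds shown here, it shows that the number responds to the group at this place, the one whose other neighbour on the carbonyl carbon is an amide-type nitrogen in a ring, and that a ring of carbon only can give way to an open group with no ring and the number still goes up. Both groups are counted with 0 hydrogen-bond donors, 0 hydrogen-bond acceptors and no net charge, so the step comes without a change in those counts, and nothing measured here explains its size.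

A single step leaves open how other groups at this place would read, such as a longer unfluorinated carbon chain, a chain carrying an amine, or a carboxylic acid. It also leaves open whether the same change would give a step of similar size on a different core, such as that of compound 1.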